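Hydroxy to Amino, Repeated on a Second Core

The source may hold more compounds than are shown below. What is called first, only, known or untested is meant among the compounds shown, and "the series" means these compounds.

Compound 1 `COc1ccc(C(=O)c2ccc(OC)c3c2C=CC(C)(C)O3)c(NC(=O)CO)c1` and compound 2 `COc1ccc(C(=O)c2ccc3c(c2)C=CC(C)(C)O3)c(NC(=O)CO)c1` differ in their cores; the difference between the two cores is not broken down here. In a functional assay on A2780 cells (Homo sapiens) for antiproliferative activity, read by MTT assay, with a stated time of 48 h (a lower number here means a stronger inhibitor, a higher number a weaker inhibitor), compound 2 gives 130 nM, while compound 1 gives 420 nM. Compound 3 `COc1ccc(C(=O)c2ccc(OC)c3c2C=CC(C)(C)O3)c(NC(=O)CN)c1` carries the change amino in place of hydroxy on a saturated chain carbon bound to a carbonyl carbon on the core of compound 1, and in this assay compound 3 gives 890 nM, a step of a 2.1-fold higher number from compound 1 to compound 3 (0.33 log units; beyond the scatter). Compound 4 `COc1ccc(C(=O)c2ccc3c(c2)C=CC(C)(C)O3)c(NC(=O)CN)c1` makes the same change on the core of compound 2, read as amino in place of hydroxy on a saturated chain carbon bound to a carbonyl carbon. Compound 4 is expected to give about 270 nM, within 120 nM to 600 nM. That expectation rests on the modest step of a 2.1-fold higher number from compound 1 to compound 3 (0.33 log units; beyond the scatter), which the same change made once before. The expected step from compound 2 to compound 4 is a 2.1-fold higher number from compound 2 to compound 4 (0.32 log units; beyond the scatter).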

Compound 4, half-maximal inhibitory concentration: 590 nM
Compound 4: middle estimate off by 2.2-fold (0.34 log units), on the low side; the measured number falls inside the stated range.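

Replacing hydroxy with amino on the second core also raises the number in this assay, giving a step of a 4.5-fold higher number from compound 2 to compound 4 (0.66 log units; beyond the scatter), so the amino compound is the weaker inhibitor on both cores. The two steps point the same way, and their sizes do not differ by more than repeated measurements would allow: the same change on two cores in this assay, a 2.1-fold higher number (0.33 log units; beyond the scatter) from compound 1 to compound 3 and a 4.5-fold higher number (0.66 log units; beyond the scatter) from compound 2 to compound 4, 2.1-fold (0.33 log units) apart, within the scatter of two such steps. The change therefore carried over from one core to the other in direction and, as far as two pairs can tell, in size, but two cores cannot show that it would hold on others, and these numbers do not explain why it happens.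

The compounds shown leave open how a dimethylamino group or a carboxylic acid would behave in this place, or a longer chain carrying the hydroxy or amino group. As far as these compounds go, whether the same step appears on a third core also remains open.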